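Chloro for hydrogen on the fused ring: clearance in rat

This account rests on a few compounds, and the source may have more. Where it says the series, first, only, none or still open, it means among the compounds named here.

Measured so far:
Compound 1, `COC(=O)N(C)c1c(N)nc(-n2nc(Cc3ccccc3F)c3cc(F)ccc32)nc1N`: 1.4 mL/min/kg
Compound 2, `COC(=O)N(C)c1c(N)nc(-n2nc(Cc3c(F)ccc(F)c3F)c3ccccc32)nc1N`: 1.6 mL/min/kg

In an ADME assay (Rattus norvegicus, strain Sprauge-Dawley) for pharmacokinetics (a lower number here means slower removal, a higher number faster removal of the compound), compound 2 gives 1.6 mL/min/kg, the higher of the two numbers, though its nearest neighbour, compound 1 with 1.4 mL/min/kg, lies within the scatter of it, so the two cannot be told apart. Compound 3, `COC(=O)N(C)c1c(N)nc(-n2nc(Cc3c(F)ccc(F)c3F)c3cc(Cl)ccc32)nc1N`, differs from compound 2 by chloro in place of hydrogen on an aromatic carbon. Among the compounds with values here, no measured pair shows what such a swap does in this assay, so the step from compound 2 to compound 3 is expected to stay within the scatter, a 1.1-fold higher number from compound 2 to compound 3 (0.05 log units; within the scatter). Compound 3 is estimated at 1.8 mL/min/kg, between 0.9 mL/min/kg and 3.6 mL/min/kg.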

Compound 3, clearance: 0.9 mL/min/kg
Estimate against measurement, compound 3: 2.0-fold (0.30 log units) above, and the stated range covers the measured number.
By their numbers in this assay, from the lowest: compounds 3, 1 and 2 (each within the scatter of the next).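

In this assay, within the data shown here, this is the first measured swap on the fused ring: chloro replaces hydrogen at the carbon para to a fused ring, giving a 1.8-fold lower number from compound 2 to compound 3 (0.25 log units; within the scatter) and staying within the usual scatter. Adding this one chlorine atom therefore leaves clearance indistinguishable from that of compound 2, and the position accepts it without a measurable rise. No measurement here explains this result. On these data alone, it remains open whether a methoxy group or a nitrile on the same carbon would behave alike, and whether chloro would give a similar step with a different group on the benzyl ring.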